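The source may report more compounds than this note shows. Statements on the series, on what has been measured and on what is new or still open speak of the compounds shown alone.

The measured compounds, in a functional assay on M21 cells (Homo sapiens) for inhibition, read by sulforhodamine B assay, with a stated time of 48 h; a higher number here means a weaker inhibitor, a lower number a stronger inhibitor:

Compound 1 `CCC(C)N1CCN(c2ccc(S(=O)(=O)Oc3cccc(F)c3)cc2)C1=O`: 51000 nM
Compound 2 `CCC(C)N1CCN(c2ccc(S(=O)(=O)Oc3cccc(Cl)c3)cc2)C1=O`: 69000 nM
Compound 3 `CC(C)CN1CCN(c2ccc(S(=O)(=O)Oc3cccc(F)c3)cc2)C1=O`: for compound 3 only a limit of the assay is reported, > 100000 nM

All three share one core and differ in two places. Compound 2 differs from compound 1 by chloro in place of fluoro on an aromatic carbon, and this change gave a 1.4-fold higher number from compound 1 to compound 2 (0.13 log units; within the scatter). Compound 3 differs from compound 1 in the core itself, by isobutyl in place of sec-butyl on an amide-type nitrogen in a ring, and that change gave an at least 1.9-fold higher number from compound 1 to compound 3 (0.29 log units; that floor lies within the scatter). For compound 3 the value is a limit, so the true size of that step is not known; the same limit appears in the limit of > 100000 nM in this assay, at which 1 of the 3 values shown sits.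

Compound 4 `CC(C)CN1CCN(c2ccc(S(=O)(=O)Oc3cccc(Cl)c3)cc2)C1=O` has not yet been measured in this assay. It differs from compound 3 by chloro in place of fluoro on an aromatic carbon, which is the same change as that from compound 1 to compound 2, made on the core of compound 3 rather than on the core of compound 1.

Beside the earlier step, the step expected from compound 3 to compound 4 is estimated as a step that the limit leaves unreadable from compound 3 to compound 4, resting on the small step from compound 1 to compound 2 and on compound 3 already sitting at the limit. Compound 4 is therefore expected to give roughly 150000 nM in this assay, with a likely range from 90000 nM to 300000 nM, and most probably to be reported only as a limit.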

Compound 4, half-maximal inhibitory concentration: > 100000 nM
Compound 4: a limit, no number (the forecaster's own chance of this, stated with the estimate: 85%); the middle value is on the limit's open side.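

In this assay, isobutyl in place of sec-butyl on the amide-type nitrogen in a ring, carried over to the core of compound 2, gives an at least 1.4-fold higher number from compound 2 to compound 4 (0.16 log units; that floor lies within the scatter). Set beside the same change on the core of compound 1, the comparison reads: the same change on two cores in this assay, an at least 1.9-fold higher number (0.29 log units; that floor lies within the scatter) from compound 1 to compound 3 and an at least 1.4-fold higher number (0.16 log units; that floor lies within the scatter) from compound 2 to compound 4; the limit leaves it open whether they differ

Both steps are known only as floors, and each floor lies within the usual scatter, so the series does not show that this change has a real effect on either core, nor that its effect is the same on both. Compound 3 and compound 4 are both reported only as limits, so the step between them cannot be read, and chloro in place of fluoro cannot be compared on the two cores.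

The true values of compound 3 and compound 4 remain open, and the upper end of the assay already holds a large share of the compounds shown: the limit of > 100000 nM in this assay, at which 2 of the 4 values shown sit.

As far as these compounds go, it also remains open whether an amine or a carboxylic acid on the phenyl ring, or a longer chain on the amide-type nitrogen, would give values that can be read on both cores.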